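A 3-methylpyridin-4-yl Exchange on Compound 3

The source may report more compounds than this note shows. Statements on the series, on what has been measured and on what is new or still open speak of the compounds shown alone.

In a functional assay on MCF7 cells (Homo sapiens) for cytotoxicity, read by CellTiter-Glo, with a stated time of 5 days (a lower number here means a stronger inhibitor, a higher number a weaker inhibitor), compound 1 (`CC/C(=C(/c1ccc(/C=C/C(=O)O)cc1)c1ccc2[nH]ncc2c1)c1cccc(Cl)c1`) gives 12 nM while compound 2 (`CC/C(=C(/c1ccc(/C=C/C(=O)O)cc1)c1ccc2[nH]ncc2c1)c1cccc(C#N)c1`) gives 100 nM and compound 3 (`CC/C(=C(/c1ccc(/C=C/C(=O)O)cc1)c1ccc2[nH]ncc2c1)c1ccc(C#N)cc1C`) gives 5 nM as the lowest number of the three. Compound 4 (`CC/C(=C(/c1ccc(/C=C/C(=O)O)cc1)c1ccc2[nH]ncc2c1)c1ccncc1C`) has not yet been measured. It carries 3-methylpyridin-4-yl in place of 4-cyano-2-methylphenyl on a double-bonded chain carbon bound to a double-bonded chain carbon and a saturated chain carbon.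

For the measured compounds named here, three measured steps concern this same place: a modest one (an 8.3-fold higher number from compound 1 to compound 2 (0.92 log units; beyond the scatter)), a second modest one (a 2.4-fold lower number from compound 1 to compound 3 (0.38 log units; beyond the scatter)) and a large one (a 20-fold lower number from compound 2 to compound 3 (1.30 log units; beyond the scatter)). Each exchange there moved the number in this assay beyond the scatter, which suggests that a further exchange may do so too. Going by the values given here, none of these steps brings a hetero atom into the ring, however, so they indicate a likely size and offer no direct precedent. Compound 3 already stands lowest (5 nM) among the three, so a higher number is expected for the new compound rather than a lower one. The expected step is of modest to large size (a 6.0-fold higher number from compound 3 to compound 4 (0.78 log units; beyond the scatter)). For compound 4 the estimated value is 30 nM with an expected range from 8 nM to 120 nM in this measurement.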

Compound 4, half-maximal inhibitory concentration: 16 nM
Estimate against measurement, compound 4: 1.9-fold (0.27 log units) above, within the range that was stated.
By their numbers in this assay, from the lowest: compound 3; then compounds 1 and 4 (each within the scatter of the next); then compound 2.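

A ring with a hetero atom on the double-bonded chain carbon keeps the number in this assay low, although 3-methylpyridin-4-yl does not match 4-cyano-2-methylphenyl, with a 3.2-fold higher number from compound 3 to compound 4 (0.51 log units; beyond the scatter). The same group recovers most of what 3-cyanophenyl loses, with a 6.3-fold lower number from compound 2 to compound 4 (0.80 log units; beyond the scatter), and it cannot be told apart from 3-chlorophenyl, with a 1.3-fold higher number from compound 1 to compound 4 (0.12 log units; within the scatter), so this smaller ring with its hetero atom serves at this place about as well as the chloro-substituted carbon ring. Nothing available here explains any of these differences.

The exchange from compound 3 to compound 4 removes the nitrile and brings the ring nitrogen in at the same time, so the compounds shown cannot assign the step to either change alone. It also remains open how much the methyl contributes to the number in this assay, since neither the plain pyridin-4-yl nor the 2-methylphenyl group is among these compounds, and an amine on the ring would test this place in a different way.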